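A Nitro Group Enters Where Two Limits Stand

The compounds below may be only part of what the source reports. "The series", "measured", "known", "first", "only" and "open" are said of these compounds alone.

Compound 1 `Cc1ccc2[nH]c(=O)c(-c3nc4ccccc4[nH]3)cc2c1` was tested in a functional assay on SK-OV-3 cells (Homo sapiens) for cytotoxicity, read by MTT assay, with a stated time of 48 h; on this read-out higher numbers stand for weaker inhibition and lower numbers for stronger inhibition. Compound 1 gives > 100000 nM, which is a limit of the assay rather than a number. Compound 2 `COc1ccc2[nH]c(=O)c(-c3nc4ccccc4[nH]3)cc2c1` likewise gives > 100000 nM in this assay, again a limit. Among the compounds with values here, the only change between these two is a step that the two limits leave unreadable from compound 1 to compound 2, and its size cannot be read because of the limit of > 100000 nM in this assay, at which 2 of the 2 values shown sit. Compound 3 `Cc1ccc2[nH]c(=O)c(-c3nc4cc([N+](=O)[O-])ccc4[nH]3)cc2c1` differs from compound 1 by nitro in place of hydrogen on an aromatic carbon. Within the data shown here, no measured step bears directly on this change, and the only measured step is itself unreadable, so nothing fixes the size or direction of an expectation. Compound 3 is therefore expected to remain weak, with its step of an at least 1.2-fold lower number from compound 1 to compound 3 (0.09 log units; that floor lies within the scatter) estimated only within broad bounds. In this assay compound 3 is estimated at 80000 nM, spanning 15000 nM to 300000 nM.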

Compound 3, half-maximal inhibitory concentration: > 100000 nM
Compound 3 ended at the assay's limit; the forecaster's own chance of this, stated with the estimate: 60%; middle value at least 1.2-fold (0.09 log units) away from the limit.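

Within the data shown here, compound 3 stays at the same limit as compound 1 in this assay, so no step between compound 1 and compound 3 can be read: the limit of > 100000 nM in this assay, at which 3 of the 3 values shown sit. The compounds shown leave open whether nitro or methoxy on the shared core moves the read-out at all, and in which direction.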